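From thiophen-2-yl to 3-chlorophenyl on a shared core

This account rests on a few compounds, and the source may have more. Where it says the series, first, only, none or still open, it means among the compounds named here.

Of the compounds shown here, two with the same core have been measured in a functional assay on MOLT-4 cells (Homo sapiens) for cytotoxicity, read by CCK-8 assay, with a stated time of 24 h; a higher number here means a weaker inhibitor, a lower number a stronger inhibitor. Compound 1 `C=CC(=O)N1C(=O)CC(c2ccc(C)cc2)Sc2ccccc21` gives 87600 nM, while compound 2 `C=CC(=O)N1C(=O)CC(c2cccs2)Sc2ccccc21` gives 557000 nM, the higher number of the two and so the weaker inhibitor. Compound 3 `C=CC(=O)N1C(=O)CC(c2cccc(Cl)c2)Sc2ccccc21` carries 3-chlorophenyl in place of thiophen-2-yl on a saturated ring carbon, next to the ring sulfur (3-chlorophenyl in place of thiophen-2-yl on a saturated ring carbon). Going by the values given here, one measured step bears on this change: a 6.4-fold higher number from compound 1 to compound 2 (0.80 log units; beyond the scatter), with thiophen-2-yl in place of 4-methylphenyl on that same carbon. Like the 4-methylphenyl of compound 1 at 87600 nM, 3-chlorophenyl is a six-membered aromatic ring of carbon only, so a step of similar size towards a lower number is expected in this assay. Among the compounds with values here, a single step is thin evidence, and no measured compound yet carries chlorine. The expected change is a 6.6-fold lower number from compound 2 to compound 3 (0.82 log units; beyond the scatter). For compound 3 the estimated value is 85000 nM, with an expected range from 30000 nM to 250000 nM.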

Compound 3, half-maximal inhibitory concentration: 77500 nM
Beside the measured number, compound 3's estimate is 1.1-fold (0.04 log units) above it; low and high end bracket the measured number.
By their numbers in this assay, from the lowest: compounds 3 and 1 (each within the scatter of the next); then compound 2.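

In this assay, 3-chlorophenyl in place of thiophen-2-yl gives a 7.2-fold lower number from compound 2 to compound 3 (0.86 log units; beyond the scatter), so among the compounds shown, both six-membered aromatic rings of carbon only give lower numbers at this saturated ring carbon than thiophen-2-yl does. Exchanging one of those rings for the other, 4-methylphenyl for 3-chlorophenyl, gives a 1.1-fold lower number from compound 1 to compound 3 (0.05 log units; within the scatter), which lies within the scatter, so this assay does not separate these two groups. No available measurement accounts for the gap between thiophen-2-yl and the two carbon-only rings.

All three groups shown here are aromatic rings, so the effect of an amine, a carboxylic acid or a longer chain on this carbon remains open. Plain phenyl would show whether the carbon-only ring gives a similar number without either methyl or chlorine.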